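A few compounds are considered here, and "the series" means these few. Any claim that something is new, unique, unknown or untested is made for them only; others in the source may bear on it.

Compound 1, `CC(C)(C)Cc1c(-c2cccc(F)c2F)sc(N)c1C(=O)c1ccc(Cl)cc1`, gives 1% in an assay on CHO cells for displacement of a labelled ligand from adenosine receptor A1 (Homo sapiens), read by scintillation counting, tested at 10 uM; on this read-out higher numbers stand for more inhibition at the one concentration tested (going by the name of the read-out) and lower numbers for less inhibition.
Compound 2, `COc1ccccc1-c1sc(N)c(C(=O)c2ccc(Cl)cc2)c1CC(C)(C)C`, gives 1% in this assay.
Compound 3, `Cc1ccc(-c2sc(N)c(C(=O)c3ccc(Cl)cc3)c2CC(C)(C)C)cc1`, gives 1% in this assay.

All three compounds share one core and differ only in the aromatic group attached to one carbon of that core. None of them displaces the labelled ligand to any noticeable degree. Compound 3 therefore stands level with the other two: no change at the digits printed from compound 1 to compound 3 (within the scatter), no change at the digits printed from compound 2 to compound 3 (within the scatter), and between the other pair no change at the digits printed from compound 1 to compound 2 (within the scatter). Three different six-membered aromatic groups at this position all leave this assay at the floor of the read-out.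

Compound 4, `CC(C)(C)Cc1c(-c2ccsc2)sc(N)c1C(=O)c1ccc(Cl)cc1`, continues this series with a change of ring type: thiophen-3-yl in place of 4-methylphenyl on an aromatic carbon. Among the measured compounds shown here, the steps that bear on it are the three above, each of which shows no movement at all when the group at this carbon is exchanged. A thiophen-3-yl ring is smaller and carries a sulfur, but nothing measured here suggests that any group at this carbon lifts inhibition above the scatter. The expected step is accordingly a number 1 percentage points higher from compound 3 to compound 4 (within the scatter), no change beyond the scatter. Compound 4 is expected to give about 2% in this assay, within a range from -8% to 12%.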

Compound 4, a percentage reported as inhibition, at one concentration (the size of the read-out at that concentration, not a potency): 2%
Compound 4: the middle estimate sits on the measured number at the digits printed; low and high end bracket the measured number.
By their numbers in this assay, from the lowest: compounds 1, 2, 3 and 4 (each within the scatter of the next).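

Compound 4 brings the first five-membered aromatic ring to this carbon, and the thiophen-3-yl group gives a number 1 percentage points higher from compound 3 to compound 4 (within the scatter) and a number 1 percentage points higher from compound 2 to compound 4 (within the scatter) and a number 1 percentage points higher from compound 1 to compound 4 (within the scatter) in this assay on this read-out. The earlier compounds shown here carried only six-membered aromatic rings of carbon at this position, so the flat result now also covers a smaller ring that holds a sulfur and counts 1 hydrogen-bond acceptor, and none of these exchanges moves the number beyond the usual scatter. Nothing available here explains why inhibition stays so low across all four compounds.

All four compounds keep an aromatic ring at this carbon, which leaves open whether a group of another kind there, such as an amine, a carboxylic acid or a longer chain of carbon atoms, would lift the number clear of the scatter. All four also share the neopentyl group, the amino group and the (4-chlorophenyl)carbonyl group, so what an exchange of any of these would do in this assay remains an open question as well.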